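The source may report more compounds than this note shows. Statements on the series, on what has been measured and on what is new or still open speak of the compounds shown alone.

Measured compounds in an in vivo ADME assay on the whole organism (strain Mongrel) for pharmacokinetics, with Canis familiaris (Canis lupus familiaris) as the target; on this read-out lower numbers stand for slow clearance and higher numbers for fast clearance:
Compound 1 `C[C@@H](NC(=O)C1(NC(=O)c2cncc(Cl)n2)CC1)c1ccc(-n2nc(Cl)c3ccccc32)cc1F` gives 10.5 mL/min/kg.
Compound 2 `C[C@@H](NC(=O)C1(NC(=O)c2cncc(Cl)c2)CC1)c1ccc(-n2nc(Cl)c3ccccc32)cc1F` gives 3.1 mL/min/kg.
Compound 3 `C[C@@H](NC(=O)C1(NC(=O)c2cncs2)CC1)c1ccc(-n2nc(Cl)c3ccccc32)cc1F` gives 1.1 mL/min/kg.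

Compound 3 shows the lowest number of the three. Its nearest neighbour is compound 2, a 2.8-fold lower number from compound 2 to compound 3 (0.45 log units; beyond the scatter), and the furthest is compound 1, a 9.5-fold lower number from compound 1 to compound 3 (0.98 log units; beyond the scatter). All three compounds share the core of compound 3 and differ only in the aromatic ring on the carbonyl carbon.

Compound 4 `C[C@@H](NC(=O)C1(NC(=O)c2cncc(Br)c2)CC1)c1ccc(-n2nc(Cl)c3ccccc32)cc1F` has not yet been measured in this assay. The change from compound 3 is 5-bromopyridin-3-yl in place of 1,3-thiazol-5-yl on a carbonyl carbon. Compound 4 is therefore the bromine counterpart of compound 2, which carries chlorine where compound 4 carries bromine. The step that bears directly on this change is a 2.8-fold lower number from compound 2 to compound 3 (0.45 log units; beyond the scatter), read in reverse, since that step replaced the chloropyridinyl ring with the thiazolyl ring. The step of a 3.4-fold lower number from compound 1 to compound 2 (0.53 log units; beyond the scatter) also shows that the chloropyridinyl ring sits well below the chloropyrazinyl ring in this assay. Compound 4 is thus expected to move back toward the number of compound 2, a step of a 3.2-fold higher number from compound 3 to compound 4 (0.50 log units; beyond the scatter) upward in this assay, beyond the scatter. The estimate for compound 4 in this assay is 3.5 mL/min/kg, with a range of 1.5 mL/min/kg to 8 mL/min/kg.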

Compound 4, clearance: 3.8 mL/min/kg
The estimate for compound 4 lay 1.1-fold (0.04 log units) below the measured number; measured number inside the range.
By their numbers in this assay, from the lowest: compound 3; then compounds 2 and 4 (each within the scatter of the next); then compound 1.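

In this assay, bromo in place of chloro on an aromatic carbon stays within the scatter (a 1.2-fold higher number from compound 2 to compound 4 (0.09 log units; within the scatter)), so compound 2 and compound 4 cannot be ordered and this halogen exchange on the pyridinyl ring gives no measurable change. The 5-bromopyridin-3-yl group also stands apart from the 1,3-thiazol-5-yl group (a 3.5-fold higher number from compound 3 to compound 4 (0.54 log units; beyond the scatter)), which shows that the gap first seen with the chlorine analogue is not confined to chlorine. It likewise remains separate from the 6-chloropyrazin-2-yl group (a 2.8-fold lower number from compound 1 to compound 4 (0.44 log units; beyond the scatter)), so both bromine and chlorine on the pyridinyl ring sit between the two other rings.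

Open, on these data alone, is whether an amine, a methoxy group or a nitrile in place of the halogen on the pyridinyl ring, or a methyl group on the 1,3-thiazol-5-yl ring, would shift the number. Nothing available here accounts for any of these steps.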